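The source may report more compounds than this note shows. Statements on the series, on what has been measured and on what is new or still open speak of the compounds shown alone.

Of the compounds shown here, three with a shared core have been measured in an ADME assay (liver) for pharmacokinetics, with Liver microsome (Rattus norvegicus) as the target, read by LC-MS, using microsomes, tested at 2 uM; a higher number here means faster removal of the compound, a lower number slower removal. Compound 1 (`O=C(N[C@@H]1CCCC[C@H]1O)c1cnc(OC2CCCC2)c(-c2cc(C(F)(F)F)ccc2Cl)c1`) gives 0.367 mL/min/kg, compound 2 (`O=C(N[C@@H]1CCCC[C@H]1O)c1cnc(OC2CCCCC2)c(-c2ccc(Cl)cc2)c1`) gives 0.662 mL/min/kg, and compound 3 (`O=C(N[C@@H]1CCCC[C@H]1O)c1cnc(Oc2ccccc2)c(-c2ccc(Cl)cc2)c1`) gives 0.353 mL/min/kg. Compound 3 therefore stands level with the other two, since all three numbers lie within the usual scatter of repeated measurements.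

Compound 4 (`O=C(N[C@@H]1CCCC[C@H]1O)c1cnc(OC2CCC2)c(-c2ccc(Cl)cc2)c1`) is compound 3 with one change: cyclobutyl in place of phenyl on an oxygen on an aromatic ring. Phenoxy becomes cyclobutyloxy, so a four-membered non-aromatic ring of carbon replaces the six-membered aromatic ring on that oxygen.

Going by the values given here, only one measured step bears closely on this. In a 1.9-fold lower number from compound 2 to compound 3 (0.27 log units; within the scatter), phenyl took the place of cyclohexyl on the same oxygen, and the size of that step stayed within the scatter. Compound 1 differs from compound 3 in more than one place, so it offers no clean comparison, and cyclobutyl itself has not been measured here. Compound 2, with cyclohexyl on that oxygen, gives 0.662 mL/min/kg, so a slightly higher number in this assay is expected, but no step beyond the scatter. The expected change is a 1.3-fold higher number from compound 3 to compound 4 (0.11 log units; within the scatter). For compound 4 the estimated clearance is 0.45 mL/min/kg, with an expected range from 0.23 mL/min/kg to 0.9 mL/min/kg.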

Compound 4, clearance: 0.21 mL/min/kg
Estimate against measurement, compound 4: 2.1-fold (0.33 log units) above, outside the stated range (below it).
By their numbers in this assay, from the lowest: compounds 4, 3, 1 and 2 (each within the scatter of the next, the first and the last beyond it).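

Where the place is an oxygen on an aromatic ring, cyclobutyl in place of phenyl gives a 1.7-fold lower number from compound 3 to compound 4 (0.23 log units; within the scatter) in this assay, so the change from an aromatic ring to a small non-aromatic one cannot be told apart from repeat-measurement noise. Going by these compounds alone, the comparison between the two non-aromatic rings says more: cyclobutyl in place of cyclohexyl gives a 3.2-fold lower number from compound 2 to compound 4 (0.50 log units; beyond the scatter) and is the first single change at this position to clear the scatter, though only modestly and in just this one pair. Nothing available here accounts for that difference in terms of a measured property.

Compound 1 carries cyclopentyl on this oxygen but also differs from compound 4 in a second place, so how the number behaves between the cyclobutyl and cyclohexyl ring sizes cannot be read from a clean pair. Going by these compounds, it also remains open whether an open chain such as ethyl, or a ring holding an oxygen such as tetrahydropyranyl, would give a number closer to that of compound 4 or to that of compound 2.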